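Replacing the aromatic end of compound 3 with carbamoyl

The source may hold more compounds than are shown below. What is called first, only, known or untested is meant among the compounds shown, and "the series" means these compounds.

In a functional assay on Ehrlich cells (Mus musculus) for cytotoxicity, read by trypan blue exclusion, with a stated time of 2 h (on this read-out higher numbers stand for weaker inhibition and lower numbers for stronger inhibition), the values are:
compound 1 `C=CCNC(=S)NC1=C(C#N)C(c2ccc(Cl)cc2Cl)C2=C(CCCC2=O)N1c1ccc(S(N)(=O)=O)cc1` gives > 100 ug/mL as a limit
compound 2 `N#CC1=C(NC(=S)Nc2ccccc2)N(c2ccc(S(N)(=O)=O)cc2)C2=C(C(=O)CCC2)C1c1ccc(Cl)cc1Cl` gives 25 ug/mL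
compound 3 `N#CC1=C(NC(=S)Nc2ccc(Cl)cc2)N(c2ccc(S(N)(=O)=O)cc2)C2=C(C(=O)CCC2)C1c1ccc(Cl)cc1Cl` gives 40 ug/mL

Compound 3 stands within the scatter of compound 2 (a 1.6-fold higher number from compound 2 to compound 3 (0.20 log units; within the scatter)). Compound 1 gives only a limit. Compound 4 `N#CC1=C(NC(N)=O)N(c2ccc(S(N)(=O)=O)cc2)C2=C(C(=O)CCC2)C1c1ccc(Cl)cc1Cl` is reached through a group of 3 heavy atoms (1 carbon, 1 nitrogen, 1 oxygen; no ring) in place of a group of 10 heavy atoms (7 carbon, 1 nitrogen, 1 sulfur, 1 chlorine; one six-membered aromatic ring of carbon only), on an amine nitrogen and so carries carbamoyl, without the aromatic ring. Going by the values given here, the steps that bear on this put phenyl or 4-chlorophenyl in place of allyl, and both gave lower numbers (an at least 4.0-fold lower number from compound 1 to compound 2 (0.60 log units; beyond the scatter); an at least 2.5-fold lower number from compound 1 to compound 3 (0.39 log units; beyond the scatter)). Compound 4 also lacks such a ring, so a modest move to a higher number is expected in this assay on the evidence of those steps. The expected step is estimated as (a 2.3-fold higher number from compound 3 to compound 4 (0.35 log units; beyond the scatter)). For compound 4 the estimate is 90 ug/mL with 35 ug/mL to 200 ug/mL as the expected range.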

Compound 4, half-maximal inhibitory concentration: 75 ug/mL
The estimate for compound 4 lay 1.2-fold (0.08 log units) above the measured number, within the range that was stated.
By their numbers in this assay, from the lowest: compounds 2, 3 and 4 (each within the scatter of the next, the first and the last beyond it). At a limit, above all of these: compound 1.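

In this assay, carbamoyl on the amine nitrogen, with no aromatic ring at this end, sits within the scatter of compound 3 (a 1.9-fold higher number from compound 3 to compound 4 (0.27 log units; within the scatter)) but beyond it against compound 2 (a 3.0-fold higher number from compound 2 to compound 4 (0.48 log units; beyond the scatter)), so the reading of this change depends on the comparison made. Against the allyl-bearing compound, the floor of the step lies within the scatter (an at least 1.3-fold lower number from compound 1 to compound 4 (0.12 log units; that floor lies within the scatter)), so carbamoyl cannot be separated from that group. Compound 1 remains a limit: the limit of > 100 ug/mL in this assay, at which 1 of the 4 values shown sits.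

Going by these compounds, how a plain amine, a carboxylic acid or a longer chain would read on this nitrogen stays open.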